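A Methyl in Place of Hydrogen on Compound 3

A few compounds are considered here, and "the series" means these few. Any claim that something is new, unique, unknown or untested is made for them only; others in the source may bear on it.

Of the compounds shown here, three built on one shared core have so far been tested in a functional assay on the whole organism (strain Wistar Albino) for inhibition, with Rattus norvegicus as the target, read by paw edema, with a stated time of 4 h, at a dose of 20 mg/kg; a lower number here means less inhibition, a higher number more inhibition at the dose given (going by the name of the read-out). Compound 1 `Cc1occc1-c1nnc2sc(-c3ccnc4ccccc34)nn12` gives 23.4% there, compound 2 `Cc1occc1-c1nnc2sc(-c3ccnc(F)c3)nn12` gives 24.4%, and compound 3 `COc1ccc2[nH]cc(Cc3nn4c(-c5ccoc5C)nnc4s3)c2c1` gives 30.8%. Compound 3 shows the highest of the three numbers, but its nearest neighbour, compound 2, lies only a little lower, and the furthest, compound 1, is also within the usual scatter of such measurements, so the three read as one level rather than as an order.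

Compound 4 `COc1ccc2[nH]c(C)c(Cc3nn4c(-c5ccoc5C)nnc4s3)c2c1` has not yet been measured. It differs from compound 3 in a single place: methyl in place of hydrogen on an aromatic carbon. Among the compounds with values here, no pair of measured compounds in this set differs in a comparable single place, so there is no measured step to lean on. The change is small and adds no donor, acceptor or charge, and the three measured values themselves sit close together, so the writer expects a step from compound 3 to compound 4 of a number 1.2 percentage points higher from compound 3 to compound 4 (within the scatter), that is, none beyond the scatter.

For compound 4 the estimated inhibition in this assay is therefore 32%, with a range from 20% to 44%.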

Compound 4, a percentage reported as inhibition, in the whole organism at one dose (the size of the read-out at that dose, not a potency): 31.2%
For compound 4 the middle estimate is 0.8 percentage points above the measured one; measured number inside the range.
By their numbers in this assay, from the lowest: compounds 1, 2, 3 and 4 (each within the scatter of the next).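

Within the data shown here, the first step in this set between compounds that differ in one place reads, in this assay, as a number 0.4 percentage points higher from compound 3 to compound 4 (within the scatter). It shows that at this position, on an aromatic carbon of a five-membered aromatic ring with 1 nitrogen, next to the ring nitrogen and next to the ring atom that bears a large group, methyl can take the place of hydrogen without the number moving beyond the scatter, something compounds 1, 2 and 3 could not show, as no two of them differ in a single place. Nothing measured in this account bears on why the number holds at this position, so the result stands as an observation only.

Going by these compounds, whether an ethyl group, an amine or a carboxylic acid at the same position would also leave the number at this level remains open, and one methyl step cannot tell how much room the position allows. The compounds shown also leave open whether the same change on another aromatic carbon of compound 3 would read the same way, and how the number would behave at any other dose or time.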